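Series notes: methoxy in place of hydrogen, cytotoxicity

The source may report more compounds than this note shows. Statements on the series, on what has been measured and on what is new or still open speak of the compounds shown alone.

Compound 1 `Oc1ccc(CNc2ncnc3c2ncn3C2CCCCO2)cc1` gives in an ADME assay on K562 cells (Homo sapiens) for cytotoxicity, with a stated time of 72 h (on this read-out lower numbers stand for stronger inhibition and higher numbers for weaker inhibition), only a limit, > 100000 nM. Compound 3 `COc1cc(CNc2ncnc3c2ncn3C2CCCCO2)ccc1O` likewise reaches only a limit, > 100000 nM. Going by the values given here, compound 2 `COc1ccccc1CNc1ncnc2c1ncn2C1CCCCO1` gives 97000 nM in this assay, the one number in the set. The cores of compound 1 and compound 2 differ by 2-methoxyphenyl in place of 4-hydroxyphenyl on a saturated chain carbon bound to a nitrogen on an aromatic ring; the step is an at least 1.0-fold lower number from compound 1 to compound 2 (0.01 log units; that floor lies within the scatter). From compound 1 to compound 3 the change is methoxy in place of hydrogen on an aromatic carbon, and the step is a step that the two limits leave unreadable from compound 1 to compound 3 because the limit of > 100000 nM in this assay, at which 2 of the 3 values shown sit, hides its size. Compound 4 `COc1cccc(OC)c1CNc1ncnc2c1ncn2C1CCCCO1` carries the same kind of change from compound 2, (methoxy in place of hydrogen on an aromatic carbon); here the place is ortho to a large group and meta to a methoxy group, whereas in compound 3 it is ortho to a hydroxy group and meta to a large group. With compound 2 at 97000 nM and the earlier step unreadable, the expected step is a 1.0-fold higher number from compound 2 to compound 4 (0.01 log units; within the scatter), likely small. Compound 4 is estimated at 100000 nM, between 40000 nM and 300000 nM, with a real chance that only a limit is returned.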

Compound 4, half-maximal inhibitory concentration: 10300 nM
For compound 4 the middle estimate is 9.7-fold (0.99 log units) above the measured one; measured number outside the range, below it.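

In this assay, methoxy in place of hydrogen, ortho to a large group and meta to a methoxy group, gives a 9.4-fold lower number from compound 2 to compound 4 (0.97 log units; beyond the scatter). This is a single readable case of the change, and it does not show that the step carries over to another core. The same change on the core of compound 1 gives a step that cannot be read, so the two cores cannot be compared, because of this limit: the limit of > 100000 nM in this assay, at which 2 of the 4 values shown sit.

The compounds shown leave open whether an amine or a carboxylic acid at the same place would give a step of similar size. Also open, on these data alone, is whether an ethoxy group there would match methoxy.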